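Chain-tail variation on the chromone core: notes

The source may hold more compounds than are shown below. What is called first, only, known or untested is meant among the compounds shown, and "the series" means these compounds.

Measured so far, in a functional assay on MCF7 cells (Homo sapiens) for antiproliferative activity, read by MTT assay; a lower number here means a stronger inhibitor, a higher number a weaker inhibitor:
compound 1 `CCCC/C=C\CCCCCCCCCc1cc(=O)c2c(O)cc(OCOC)c(C)c2o1`: > 67200 nM, a limit of the assay
compound 2 `CCCC/C=C\CCCCCCCCCc1cc(=O)c2c(O)cc(OCOC)cc2o1`: > 67200 nM, a limit of the assay

Compound 1 stands only at a limit in this assay. Both values shown sit there (the limit of > 67200 nM in this assay, at which 2 of the 2 values shown sit). Among the compounds with values here, the single measured step, a step that the two limits leave unreadable from compound 1 to compound 2, cannot be read from two limits and says nothing about chain changes.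

Compound 3 `CCCCC/C=C\C/C=C\CCCCCCCc1cc(=O)c2c(O)cc(OCOC)c(C)c2o1` differs from compound 1 by deca-1,4-dien-1-yl in place of oct-3-en-1-yl on a saturated chain carbon, seven bonds along the chain from an aromatic carbon. Within the data shown here, no measured step bears on this change; the only evidence is that compound 1 is at the limit, with the chain otherwise unchanged. The expected step that the limit leaves unreadable from compound 1 to compound 3 is therefore no readable change beyond the scatter, and a limit again is the most likely read-out. Compound 3 is estimated at 80000 nM, within 25000 nM to 250000 nM.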

Compound 3, half-maximal inhibitory concentration: > 84100 nM
Compound 3: a limit, no number (the forecaster's own chance of this, stated with the estimate: 75%); middle value at least 1.0-fold (0.02 log units) from the limit.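

In this assay compound 3 gives > 84100 nM, a limit of the assay and not a number. Within the data shown here, compound 1 also stands at a limit, so no step between compound 1 and compound 3 can be read. The compounds shown leave open whether any chain on the shared core gives a measurable value in this assay.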